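The source may report more compounds than this note shows. Statements on the series, on what has been measured and on what is new or still open speak of the compounds shown alone.

Measured so far in a functional assay on PC-3 cells (Homo sapiens) for cytotoxicity, read by WST assay, with a stated time of 72 h; a lower number here means a stronger inhibitor, a higher number a weaker inhibitor:
- compound 1 `O=C1Nc2ccccc2C1(c1ccc(O)cc1)C1CCCCCC1`: > 1000 nM
- compound 2 `Cc1cccc2c1NC(=O)C2(c1ccc(O)cc1)C1CCCCCC1`: > 1000 nM
- compound 3 `Cc1cc(C)c2c(c1)C(c1ccc(O)cc1)(C1CCCCCC1)C(=O)N2`: > 1000 nM

Each of these values is a limit and not a number. Compound 2 therefore has no exact place on the scale: it stands at > 1000 nM, which is a limit. Its neighbours offer no better footing, and the whole set comes down to the limit of > 1000 nM in this assay, at which 3 of the 3 values shown sit.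

Compound 4 `COc1ccc2c(c1C)NC(=O)C2(c1ccc(O)cc1)C1CCCCCC1` differs from compound 2 in one place: methoxy in place of hydrogen on an aromatic carbon. In words, this is methoxy in place of hydrogen on an aromatic carbon, ortho to a methyl group.

Among the measured compounds shown here, two measured steps touch compound 2, a step that the two limits leave unreadable from compound 1 to compound 2 and a step that the two limits leave unreadable from compound 2 to compound 3, and both are changes of methyl in place of hydrogen on an aromatic carbon. For the measured compounds named here, neither has a size that can be read, and no measured step involves methoxy. They therefore give no firm size or direction for the new change in this assay. The expected result is a step that the limit leaves unreadable from compound 2 to compound 4, with a fair chance that only a limit is reported again. For compound 4 the estimate is 2000 nM, with an expected range from 300 nM to 10000 nM as the outer ends.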

Compound 4, half-maximal inhibitory concentration: 12 nM
Estimate against measurement, compound 4: 170-fold (2.22 log units) above; measured number below the stated range.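

In this assay, among the compounds shown here, the two methyl steps among the earlier compounds cannot be read, and so they gave no sign that a change on the aromatic ring of the shared core could move the result at all. A methoxy group ortho to a methyl group now produces an at least 83-fold lower number from compound 2 to compound 4 (1.92 log units; beyond the scatter), which makes this position the first in the series where a change has a readable effect, and a large one. Compound 4 is also the only compound with an exact number, while the others remain at a limit of the assay: the limit of > 1000 nM in this assay, at which 3 of the 4 values shown sit.

The compounds shown do not separate the contribution of the methoxy group from that of the methyl group ortho to it, so it remains open whether methoxy would have the same effect alone. They also leave open whether a slightly larger ethoxy group, a small fluorine atom or an amine at the same place would keep this strength, or whether it belongs to methoxy in particular.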